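The compounds below may be only part of what the source reports. "The series", "measured", "known", "first", "only" and "open" are said of these compounds alone.

Working notes on the series. In a functional assay on HOS cells (Homo sapiens) for antiproliferative activity (on this read-out lower numbers stand for stronger inhibition and higher numbers for weaker inhibition), compound 1 (`Nc1n[nH]c(N)c1/N=N/c1cccc([N+](=O)[O-])c1`) gives > 100000 nM, which is a limit and not a number. Compound 2 (`Nc1n[nH]c(N)c1/N=N/c1cccc(O)c1`) gives > 100000 nM, also a limit and not a number. Compound 2 therefore has no measured number, and its standing is given only by the limit of > 100000 nM in this assay, at which 2 of the 2 values shown sit.

Compound 3 (`Nc1n[nH]c(N)c1/N=N/c1cccc(C(=O)O)c1`) differs from compound 2 by one exchange, carboxy in place of hydroxy on an aromatic carbon.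

Among the compounds with values here, one measured step bears on this, another single exchange on an aromatic carbon, hydroxy in place of nitro: a step that the two limits leave unreadable from compound 1 to compound 2. No size can be taken from that step, and neither compound in it gives a number. With only this to go on, no step beyond the scatter is expected in this assay, and no direction can be assigned. The estimated change, a number no higher from compound 2 to compound 3 (the limit leaves the size open), is therefore expected to be unreadable or small. Compound 3 is estimated at 100000 nM, with an expected range of 30000 nM to 200000 nM, and the result may well be another limit.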

Compound 3, half-maximal inhibitory concentration: > 100000 nM
Compound 3 gave a limit, no number; the forecaster's own chance of this, stated with the estimate: 85%; the middle value lies on the limit itself.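

In this assay compound 3 gives > 100000 nM, which is a limit and not a number. No step can be read among compound 1, compound 2 and compound 3, as all of them stop at the same limit: the limit of > 100000 nM in this assay, at which 3 of the 3 values shown sit.

The compounds shown leave open how these three rank and whether any group at this place on the aromatic ring gives a measurable number.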